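The source may hold more compounds than are shown below. What is called first, only, known or untested is meant among the compounds shown, and "the series" means these compounds.

Measured so far in a functional assay on IGROV-1 cells (Homo sapiens) for cytotoxicity, read by sulforhodamine B assay, with a stated time of 48 h, tested at 100 uM; on this read-out lower numbers stand for a stronger effect and higher numbers for a weaker effect at the one concentration tested:
compound 1 `COc1cc(-c2cc(/C=C/C(=O)c3ccc(N)cc3)[nH]n2)cc(OC)c1OC` gives -49%
compound 2 `COc1cc(-c2cc(/C=C/C(=O)c3ccc(Cl)c(Cl)c3)[nH]n2)cc(OC)c1OC` gives 9%
compound 3 `COc1ccc(C(=O)/C=C/c2cc(-c3cc(OC)c(OC)c(OC)c3)n[nH]2)cc1OC` gives -73%

Compound 3 stands lowest of the three numbers, its nearest neighbour being compound 1 and its furthest compound 2; both gaps are beyond the scatter. The three measured steps all change the aryl group on the carbonyl carbon: a number 58 percentage points higher from compound 1 to compound 2 (beyond the scatter), a number 24 percentage points lower from compound 1 to compound 3 (beyond the scatter) and a number 82 percentage points lower from compound 2 to compound 3 (beyond the scatter). Among the compounds with values here, none of them removes a single methoxy group, so the next step has no direct precedent.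

Compound 4 `COc1ccc(C(=O)/C=C/c2cc(-c3cc(OC)c(OC)c(OC)c3)n[nH]2)cc1` follows from compound 3 by hydrogen in place of methoxy on an aromatic carbon. The measured steps show that changes on this ring move the read-out a long way, and that the two methoxy-bearing compounds, compound 1 and compound 3, sit at the low end. Keeping one methoxy is therefore expected to keep compound 4 in the low region, with an estimated step of a number 18 percentage points higher from compound 3 to compound 4 (beyond the scatter) toward the value of compound 1, possibly within the scatter. For compound 4 in this assay the estimate is -55%, ranging from -85% to -20%.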

Compound 4, a percentage reported as activity, at one concentration (the size of the read-out at that concentration, not a potency): -29%
For compound 4 the middle estimate is 26 percentage points below the measured one; the range from low to high includes it.
By their numbers in this assay, from the lowest: compound 3; then compound 1; then compound 4; then compound 2.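

In this assay, the step with a single methoxy group lost, 3,4-dimethoxyphenyl to 4-methoxyphenyl, is a number 44 percentage points higher from compound 3 to compound 4 (beyond the scatter) and is large, so this place on the aromatic ring, ortho to a methoxy group, clearly affects the read-out. The 4-methoxyphenyl group still gives a number 38 percentage points lower from compound 2 to compound 4 (beyond the scatter) against the 3,4-dichlorophenyl group, so one methoxy group keeps part of the effect. Among the two groups with a single substituent, methoxy in place of amino gives a number 20 percentage points higher from compound 1 to compound 4 (beyond the scatter) and ranks the 4-aminophenyl group lower on this read-out. Nothing at hand explains these steps.

The compounds shown leave open how a hydroxy group or a longer ethoxy chain at this place would compare with methoxy. They also leave open whether an unsubstituted phenyl group would extend the same trend.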